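The source may report more compounds than this note shows. Statements on the series, on what has been measured and on what is new or still open speak of the compounds shown alone.

Measured compounds:

Compound 1, `CCCc1nc(-c2ccccc2)c(CNCCN2CCN(c3ccc(Cl)cc3)CC2)o1`, gives 2820 nM in an assay on HEK293 cells for inhibition of Voltage-dependent T-type calcium channel subunit alpha-1G (Homo sapiens), read by patch clamp; a higher number here means a weaker inhibitor, a lower number a stronger inhibitor.
Compound 2, `CCCc1nc(-c2ccccc2)c(CNCCN2CCN(c3cccc(C(F)(F)F)c3)CC2)o1`, gives 1940 nM in this assay.
Compound 3, `CCCc1nc(-c2ccccc2)c(CNCCN2CCN(c3ccccc3C(F)(F)F)CC2)o1`, gives 2100 nM in this assay.

All three compounds share a common core and differ only in the aromatic group carried on the ring nitrogen of the piperazine-like six-membered ring. Compound 3 stands second highest of the three numbers, yet its distance to compound 2 and to compound 1 is in each case within the scatter, so no order among the three can be drawn from these values.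

Compound 4, `CCCc1nc(-c2ccccc2)c(CNCCN2CCN(c3ccc(OC)cc3)CC2)o1`, has not yet been measured. It differs from compound 3 as follows: 4-methoxyphenyl in place of 2-(trifluoromethyl)phenyl on an amine nitrogen in a ring.

The measured steps that bear on this change are all exchanges of the same aromatic group: a 1.5-fold lower number from compound 1 to compound 2 (0.16 log units; within the scatter), a 1.3-fold lower number from compound 1 to compound 3 (0.13 log units; within the scatter), and a 1.1-fold higher number from compound 2 to compound 3 (0.03 log units; within the scatter). Each of them stayed within the scatter. Three different aromatic groups on this nitrogen have so far given indistinguishable numbers, and the methoxy-bearing group has not been tested, so nothing points to a step beyond the scatter in either direction. For compound 4 a value of 2400 nM is therefore expected, with a range from 1000 nM to 6000 nM. This estimate means a step of a 1.1-fold higher number from compound 3 to compound 4 (0.06 log units; within the scatter), expected to stay within the scatter.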

Compound 4, half-maximal inhibitory concentration: 9200 nM
Compound 4: the middle estimate sits 3.8-fold (0.58 log units) below what was measured; measured number above the stated range.
By their numbers in this assay, from the lowest: compounds 2, 3 and 1 (each within the scatter of the next); then compound 4.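

Until now, three different aromatic groups on this amine nitrogen in a ring gave numbers within the scatter of one another, so the position could have seemed indifferent to the group it carries. In this assay 4-methoxyphenyl breaks that picture, with a 4.4-fold higher number from compound 3 to compound 4 (0.64 log units; beyond the scatter) and a 4.7-fold higher number from compound 2 to compound 4 (0.68 log units; beyond the scatter) as two steps beyond the scatter. The closest comparison keeps the 4-substituted phenyl ring and changes only the group on it, and methoxy in place of chloro on an aromatic carbon still gives a 3.3-fold higher number from compound 1 to compound 4 (0.51 log units; beyond the scatter) and so a modest loss of inhibition, which shows that the identity of that group matters here and not only its place on the ring. No measurement given here accounts for this loss.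

The compounds shown leave open whether the higher number belongs to methoxy as such or to methoxy at this ring position, which 2-methoxyphenyl and 3-methoxyphenyl would help to separate. They also leave open how an unsubstituted phenyl, a 4-hydroxyphenyl or a 4-ethoxyphenyl group would compare on the same core.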